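Swapping the Substituted Phenyl Group on a Shared Core

A few compounds are considered here, and "the series" means these few. Any claim that something is new, unique, unknown or untested is made for them only; others in the source may bear on it.

- compound 1 `CCC1=C(O)c2c(oc(-c3cccc(OC)c3)cc2=O)C(CC)(CC)C1=O` gives 13.3 uM
- compound 2 `CCC1=C(O)c2c(oc(-c3ccc(C)c(F)c3)cc2=O)C(CC)(CC)C1=O` gives 28.1 uM
- compound 3 `CCC1=C(O)c2c(oc(-c3ccc(OC)c(Cl)c3)cc2=O)C(CC)(CC)C1=O` gives 24.9 uM

These three compounds share one core and differ only in the substituted phenyl group attached to it. In a functional assay on KB cells (Homo sapiens) for antiproliferative activity, read by sulforhodamine B assay, with a stated time of 3 days (a higher number here means that more compound is needed for the effect, a lower number that less compound is needed), compound 3 (24.9 uM) stands close to both of the others. Two steps place it: a 1.1-fold lower number from compound 2 to compound 3 (0.05 log units; within the scatter) and a 1.9-fold higher number from compound 1 to compound 3 (0.27 log units; within the scatter) are both small.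

The next compound, compound 4 `CCC1=C(O)c2c(oc(-c3cc(C)ccc3C)cc2=O)C(CC)(CC)C1=O`, carries 2,5-dimethylphenyl in place of 3-chloro-4-methoxyphenyl on an aromatic carbon next to the ring oxygen (2,5-dimethylphenyl in place of 3-chloro-4-methoxyphenyl on an aromatic carbon).

Among the measured compounds shown here, no measured compound carries 2,5-dimethylphenyl, so the evidence is indirect. All three measured steps exchange one substituted phenyl group for another at this same place. The largest of them, a 2.1-fold higher number from compound 1 to compound 2 (0.32 log units; beyond the scatter), only just clears the scatter. Replacing this group has therefore moved the number little so far, though three compounds are a narrow base. Expected in this assay is a 1.1-fold lower number from compound 3 to compound 4 (0.05 log units; within the scatter), an estimated change no larger than the scatter and with no clear direction. Compound 4 is expected at 22 uM (estimated range 10 uM to 48 uM).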

Compound 4, concentration for half-maximal effect: 14.5 uM
Beside the measured number, compound 4's estimate is 1.5-fold (0.18 log units) above it, within the range that was stated.
By their numbers in this assay, from the lowest: compounds 1, 4, 3 and 2 (each within the scatter of the next, the first and the last beyond it).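

In this assay 2,5-dimethylphenyl, whose substituents hold carbon only, takes the place of 3-chloro-4-methoxyphenyl with a 1.7-fold lower number from compound 3 to compound 4 (0.23 log units; within the scatter) and so the loss of the chlorine, the oxygen and the one hydrogen-bond acceptor of the leaving group does not move the number beyond the usual scatter. The two other new steps, a 1.9-fold lower number from compound 2 to compound 4 (0.29 log units; within the scatter) and a 1.1-fold higher number from compound 1 to compound 4 (0.04 log units; within the scatter) as well, also stay within that scatter, which means compound 4 cannot be told apart from any of the three earlier compounds, even though compound 1 and compound 2 lie just beyond the scatter from each other. Nothing available explains why these differently substituted phenyl groups give such similar numbers.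

Going by these compounds, all four groups at this place are phenyl rings with small substituents, so it remains open whether the numbers stay this close with an unsubstituted phenyl, with a phenyl carrying an amine or a carboxylic acid, or with a longer chain in place of the ring. All four compounds also share one core, so whether the same holds with other groups elsewhere on that core is open too.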